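Thiophenyl in Place of Chlorophenyl on a Shared Core

The compounds below may be only part of what the source reports. "The series", "measured", "known", "first", "only" and "open" are said of these compounds alone.

Of the compounds shown here, three on one shared core have been measured in a functional assay on HT-29 cells (Homo sapiens) for inhibition, read by sulforhodamine B assay, with a stated time of 48 h, tested at 10 uM; a lower number here means less inhibition, a higher number more inhibition at the concentration tested (going by the name of the read-out). Compound 1 `Brc1cn2ccnc2c(-c2ccc3ncn(C4CCCCC4)c3c2)n1` carries a bromo group and gives 5.21%. Compound 2 `c1ccc(-c2cn3ccnc3c(-c3ccc4ncn(C5CCCCC5)c4c3)n2)cc1` gives 48.3%, and compound 3 `Clc1ccc(-c2cn3ccnc3c(-c3ccc4ncn(C5CCCCC5)c4c3)n2)cc1` gives 16.4%. Compound 3 therefore stands second of the three numbers: the step of a number 11.2 percentage points higher from compound 1 to compound 3 (beyond the scatter) places it beyond the scatter above compound 1, while a number 31.9 percentage points lower from compound 2 to compound 3 (beyond the scatter) leaves it far beneath compound 2.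

Compound 4 `c1csc(-c2cn3ccnc3c(-c3ccc4ncn(C5CCCCC5)c4c3)n2)c1` is reached from compound 3 by a single change: thiophen-2-yl in place of 4-chlorophenyl on an aromatic carbon. Among the compounds with values here, no measured step exchanges one aromatic ring for another, so the closest guides are indirect. The step of a number 31.9 percentage points lower from compound 2 to compound 3 (beyond the scatter) shows that adding a chloro to the phenyl costs a large share of inhibition, and a number 43.1 percentage points higher from compound 1 to compound 2 (beyond the scatter) shows that an unsubstituted phenyl in this position raises it strongly from the bromo compound. Both point the same way: a ring without the chloro, as in compound 2, sits well above the chlorinated one. Thiophen-2-yl carries no chloro, yet it is a five-membered ring with one hetero atom rather than a phenyl, so the full height of compound 2 is not assumed. The step of a number 18.6 percentage points higher from compound 3 to compound 4 (beyond the scatter) is expected to be a rise beyond the scatter. Compound 4 is thus estimated at 35% in this assay, within a range from 15% to 55%.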

Compound 4, a percentage reported as inhibition, at one concentration (the size of the read-out at that concentration, not a potency): 0.09%
Compound 4: the middle estimate sits 34.9 percentage points above what was measured; measured number below the stated range.
By their numbers in this assay, from the lowest: compounds 4 and 1 (each within the scatter of the next); then compound 3; then compound 2.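

The step of a number 48.2 percentage points lower from compound 2 to compound 4 (beyond the scatter) in this assay shows that at this position, on an aromatic carbon next to the ring nitrogen, an aromatic ring free of chloro does not by itself secure a high number. The step of a number 16.3 percentage points lower from compound 3 to compound 4 (beyond the scatter) adds that thiophen-2-yl also falls short of 4-chlorophenyl, so the order of the rings at this place cannot be read from the chloro alone. With the step of a number 5.1 percentage points lower from compound 1 to compound 4 (within the scatter) as the last comparison, thiophen-2-yl cannot be told apart from bromo, so the earlier impression that an aromatic ring here lifts inhibition over bromo holds for compounds 2 and 3, while compound 4 goes against it.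

On these data alone, what remains open is whether the high number of compound 2 needs a six-membered aromatic ring of carbon only, which a comparison with thiophen-3-yl, pyridin-3-yl or a 4-methoxyphenyl group at the same carbon could begin to settle. Why thiophen-2-yl behaves as it does here is something the available evidence does not address.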